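Nitro to methyl on the amide aryl ring

The compounds below may be only part of what the source reports. "The series", "measured", "known", "first", "only" and "open" are said of these compounds alone.

Measured so far:
compound 1 `O=C(Nc1cc(Sc2ncn[nH]2)c(O)c2ccccc12)c1cccc([N+](=O)[O-])c1` gives 26900 nM
compound 2 `O=C(Nc1cc(Sc2nncs2)c(O)c2ccccc12)c1ccc(Cl)cc1` reaches only > 100000 nM, a limit of the assay
compound 3 `O=C(Nc1cc(Sc2ncnc3nc[nH]c23)c(O)c2ccccc12)c1ccc([N+](=O)[O-])cc1` reaches only > 100000 nM, a limit of the assay

Going by the values given here, in a functional assay on PC-3 cells (Homo sapiens) for antiproliferative activity, read by MTT assay, with a stated time of 48 h (a higher number here means a weaker inhibitor, a lower number a stronger inhibitor), compound 1 gives 26900 nM, the only number in the set. Among the compounds with values here, the two other compounds sit at the limit of > 100000 nM in this assay, at which 2 of the 3 values shown sit, so compound 1 stands alone as the sole measured value and cannot be ranked against them. Compound 4 `Cc1cccc(C(=O)Nc2cc(Sc3ncn[nH]3)c(O)c3ccccc23)c1` differs from compound 1 by methyl in place of nitro on an aromatic carbon. Within the data shown here, no step between measured compounds is available to calibrate this change; in this assay the move is expected to stay within the usual scatter, with no clear direction. Compound 4 is therefore expected near 30000 nM, in a range from 10000 nM to 100000 nM. The expected step is a 1.1-fold higher number from compound 1 to compound 4 (0.05 log units; within the scatter).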

Compound 4, half-maximal inhibitory concentration: 59500 nM
The estimate for compound 4 lay 2.0-fold (0.30 log units) below the measured number; the range from low to high includes it.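

Going by these compounds alone, a step of a 2.2-fold higher number from compound 1 to compound 4 (0.34 log units; beyond the scatter) in this assay is the only readable step, and it shows that this position responds to the change from 3-nitrophenyl to 3-methylphenyl. Compound 4 still gives a measured value (59500 nM) rather than a limit, so nitro is not needed for a measurable value on this core. Nothing available accounts for the size of this step.

Open, as far as these compounds go, is how an amine or a carboxylic acid at this position would compare with nitro and methyl. Also open, from the compounds shown here alone, is whether nitro or methyl would give the same step on the other positions of the ring.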